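Lengthening an alkyl chain on a shared core, one carbon at a time

A few compounds are considered here, and "the series" means these few. Any claim that something is new, unique, unknown or untested is made for them only; others in the source may bear on it.

Compound 1 `Cc1ccc(-n2nc(-c3ccc(C(F)(F)F)cc3O)nc2-c2ccccc2O)cc1` and compound 2 `CCc1ccc(-n2nc(-c3ccc(C(F)(F)F)cc3O)nc2-c2ccccc2O)cc1` are built on the same core and differ only in one small side group. In a functional assay on PC-12 cells (Rattus norvegicus) for cytotoxicity, read by MTT assay, with stated times of 2 h and 24 h, tested at 1 uM (on this read-out lower numbers stand for a weaker effect and higher numbers for a stronger effect at the one concentration tested), compound 1 gives 71.5%, and in this assay compound 2 gives 64.4%. The step from the first to the second is a number 7.1 percentage points lower from compound 1 to compound 2 (within the scatter), so the two numbers cannot be told apart. Going by the values given here, compound 2 stands as the lowest of the two values measured so far, with compound 1 as its only neighbour, and that neighbour lies within the scatter of it.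

Compound 3 `CC(C)c1ccc(-n2nc(-c3ccc(C(F)(F)F)cc3O)nc2-c2ccccc2O)cc1` is the next member of this small series. It differs from compound 2 by methyl in place of hydrogen on a saturated chain carbon bound to an aromatic carbon and a saturated chain carbon. Among the compounds with values here, the one measured step that bears on this change is a number 7.1 percentage points lower from compound 1 to compound 2 (within the scatter), a comparable addition of a methyl group at a similar place, and it stayed within the scatter. Within the data shown here, with no step pointing in either direction, the expected step in this assay is a number 4.4 percentage points lower from compound 2 to compound 3 (within the scatter), nothing beyond the scatter. Compound 3 is therefore estimated to give about 60%, within a range of 45% to 75%.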

Compound 3, a percentage reported as activity, at one concentration (the size of the read-out at that concentration, not a potency): 69.7%
Compound 3: the middle estimate sits 9.7 percentage points below what was measured, and the stated range covers the measured number.
By their numbers in this assay, from the lowest: compounds 2, 3 and 1 (each within the scatter of the next).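

In this assay, going by these compounds alone, going from 4-ethylphenyl to 4-isopropylphenyl gives a number 5.3 percentage points higher from compound 2 to compound 3 (within the scatter), so adding a methyl on the saturated chain carbon bound to an aromatic carbon, which makes the chain branched for the first time, again leaves two numbers that cannot be told apart. Comparing the two ends of the series, isopropyl in place of methyl on an aromatic carbon gives a number 1.8 percentage points lower from compound 1 to compound 3 (within the scatter), so methyl, ethyl and isopropyl at this position all give readings within the scatter of one another, and neither added length nor branching shows a measurable effect here. No measurement shown here offers an explanation for these numbers, and with steps this small there is no trend to explain.

Going by these compounds, what would happen with a larger group at this position remains open, for example a longer chain such as butyl, a more branched tert-butyl group, or a different kind of group such as an amine or a carboxylic acid. On these data alone, each compound also has a reading at a single concentration only, so whether any of them would give a stronger or weaker effect at another concentration is still unknown.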